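Compound 1 to compound 4: changing the chain on the core

The source may hold more compounds than are shown below. What is called first, only, known or untested is meant among the compounds shown, and "the series" means these compounds.

Measured so far in a functional assay on HCC827 cells (Homo sapiens) for inhibition, read by fluorescence, with a stated time of 72 h; on this read-out higher numbers stand for weaker inhibition of growth and lower numbers for stronger inhibition of growth
compound 1 `CC(C)=CCn1cnc2c(Nc3cccc(Cl)c3)nc(N[C@H]3CC[C@H](N)CC3)nc21` gives 13500 nM
compound 2 `CC(C)CCn1cnc2c(NCc3cccc(Cl)c3)nc(N[C@H]3CC[C@H](N)CC3)nc21` gives 16700 nM
compound 3 `COc1cc(Nc2nc(N[C@H]3CC[C@H](N)CC3)nc3c2ncn3CCC(C)C)cc(OC)c1` gives 11200 nM

Compound 1 at 13500 nM lies within the scatter of both compound 2 and compound 3, so it holds no separate place among the three. The next compound to be measured is compound 4 `N[C@H]1CC[C@H](Nc2nc(Nc3cccc(Cl)c3)c3ncn(Cc4ccccc4)c3n2)CC1` which keeps the rest of compound 1 but puts phenyl in place of 2-methylprop-1-en-1-yl on a saturated chain carbon bound to an aromatic nitrogen. The difference is counted as phenyl in place of 2-methylprop-1-en-1-yl on a saturated chain carbon bound to an aromatic nitrogen and, cut one bond further out, reads 3-methylbut-2-en-1-yl to benzyl.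

Among the measured compounds shown here, the only measured step is a 1.5-fold lower number from compound 2 to compound 3 (0.17 log units; within the scatter) and it lies within the scatter. That step puts 3,5-dimethoxyphenyl in place of 3-chlorobenzyl on a nitrogen on an aromatic ring, which is a different place from the one changed here. For the measured compounds named here, no measured step changes this chain alone, so the data give no direct size for the change. From the compounds shown here alone, no step beyond the scatter is therefore expected in this assay and the direction stays open, although the range is kept wide. The estimated step is a 1.1-fold lower number from compound 1 to compound 4 (0.05 log units; within the scatter) and it remains only an expectation. For compound 4 the expected value is 12000 nM with an estimated range from 5000 nM to 25000 nM in this read-out.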

Compound 4, concentration for 50% growth inhibition: 13700 nM
For compound 4 the middle estimate is 1.1-fold (0.06 log units) below the measured one; the range from low to high includes it.
By their numbers in this assay, from the lowest: compounds 3, 1, 4 and 2 (each within the scatter of the next).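

On the chain at the aromatic nitrogen of the shared core, this assay now gives a first direct reading: going from 3-methylbut-2-en-1-yl to benzyl produces a 1.0-fold higher number from compound 1 to compound 4 (0.01 log units; within the scatter), with the rest of compound 1 held fixed. The earlier compounds shown here gave no step at this place, and this pair shows that an aromatic ring of carbon only can replace the 2-methylprop-1-en-1-yl end of the chain, with its double bond outside aromatic rings, without a step beyond the scatter. No measured property of these groups is available to account for the outcome.

From the compounds shown here alone, whether an amine, a carboxylic acid or a longer chain at this place would move the number beyond the scatter remains open, since both groups compared here carry no hydrogen-bond donors, no hydrogen-bond acceptors and no net charge. With no step in the series yet beyond the scatter, the compounds shown also leave open whether any single change to the shared core's substituents can strengthen inhibition of growth in this assay.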